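Working notes: from compound 1 to compound 4

The compounds below may be only part of what the source reports. "The series", "measured", "known", "first", "only" and "open" are said of these compounds alone.

Measured compounds:
compound 1, `COc1nc2ccc(Br)cc2cc1C(c1ccccc1)n1cc(C2CC2)nn1`, in an ADME assay on HEK293 cells (Homo sapiens) for cytotoxicity, read by sulforhodamine B assay, with a stated time of 48 h, tested at 10 uM; a lower number here means less inhibition, a higher number more inhibition at the concentration tested (going by the name of the read-out): 8.22%
compound 2, `COc1nc2ccc(Br)cc2cc1C(c1ccccc1)n1cc(CCCCCO)nn1`, in this assay: 7.96%
compound 3, `COc1nc2ccc(Br)cc2cc1C(c1ccccc1)n1cc(-c2ccc(F)cc2)nn1`, in this assay: 4.04%

Compound 1 has the highest of the three numbers, but the gaps to the other two are small: the step of a number 0.3 percentage points lower from compound 1 to compound 2 (within the scatter) and the step of a number 4.2 percentage points lower from compound 1 to compound 3 (within the scatter) both stay within the scatter, so the three compounds cannot be ordered on these data.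

Compound 4, `COc1nc2ccc(Br)cc2cc1C(c1ccccc1)n1cc(-c2ccccc2C(F)(F)F)nn1`, has not yet been measured. It differs from compound 1 in one place: 2-(trifluoromethyl)phenyl in place of cyclopropyl on an aromatic carbon.

The closest measured comparison is the step from compound 1 to compound 3, where a 4-fluorophenyl replaced the cyclopropyl on the same aromatic carbon, a number 4.2 percentage points lower from compound 1 to compound 3 (within the scatter), within the scatter. The step of a number 3.9 percentage points lower from compound 2 to compound 3 (within the scatter), also bringing in a 4-fluorophenyl, is likewise within the scatter. Every exchange on this aromatic carbon so far has left this assay essentially unchanged, and nothing in the data separates a 2-(trifluoromethyl)phenyl from a 4-fluorophenyl in this regard. A step in this assay beyond the scatter is therefore not expected; the estimated step is a number 2.2 percentage points lower from compound 1 to compound 4 (within the scatter).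

Compound 4 is expected to give 6%, with a range of 0% to 15%.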

Compound 4, a percentage reported as inhibition, at one concentration (the size of the read-out at that concentration, not a potency): 14.3%
For compound 4 the middle estimate is 8.3 percentage points below the measured one; measured number inside the range.
By their numbers in this assay, from the lowest: compounds 3, 2, 1 and 4 (each within the scatter of the next, the first and the last beyond it).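

Within the data shown here, at this aromatic carbon of the five-membered ring, this assay now gives the first step beyond the scatter, a number 10.3 percentage points higher from compound 3 to compound 4 (beyond the scatter), a modest step with 2-(trifluoromethyl)phenyl in place of 4-fluorophenyl. The two groups both bring a six-membered aromatic ring of carbon only, so an aromatic ring at this carbon does not by itself fix the number, and the choice of group on that ring can move it by a modest amount. The other two steps, a number 6.1 percentage points higher from compound 1 to compound 4 (within the scatter) and a number 6.3 percentage points higher from compound 2 to compound 4 (within the scatter), stay within the scatter, so compound 4 stands apart only from compound 3, and the series offers no measurement that explains the gap between these two groups.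

The compounds shown leave open whether the higher number goes with the trifluoromethyl group itself or with its placement on the phenyl ring, since only one compound carries that group. From the compounds shown here alone, it is also open how this assay would read with an unsubstituted phenyl, an amine or a carboxylic acid at this carbon.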